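Notes on the amide-type nitrogen group of compound 1

The compounds below may be only part of what the source reports. "The series", "measured", "known", "first", "only" and "open" are said of these compounds alone.

Measured values in a physicochemical assay for solubility, read by HPLC, in simulated intestinal fluid, with a stated time of 16 h, at pH 6.5, tested at 2.5 mg/mL (a lower number here means a less soluble compound, a higher number a more soluble compound), are these:
- compound 1 `CNC(=O)c1cc(C(=O)N[C@H]2[C@@H]3C[C@H](O)C[C@@H]32)cc2c1OC[C@@]2(C)c1ccccc1` gives 539 ug/mL
- compound 2 `CNC(=O)c1cc(C(=O)N[C@H]2[C@@H]3COC[C@@H]32)cc2c1O[C@H](CF)[C@H]2c1ccccc1` gives 80 ug/mL

Of these two, compound 1 stands highest, and its gap to compound 2 lies beyond the scatter. Compound 3 (`CNC(=O)c1cc(C(=O)N[C@H]2CC[C@H](O)CC2)cc2c1OC[C@@]2(C)c1ccccc1`) has not yet been measured. Its change from compound 1 is a group of 7 heavy atoms (6 carbon, 1 oxygen; one six-membered non-aromatic ring of carbon only) in place of a group of 7 heavy atoms (6 carbon, 1 oxygen; one three-membered non-aromatic ring of carbon only, one five-membered non-aromatic ring of carbon only), on an amide-type nitrogen on an amide-type nitrogen, with 4-hydroxycyclohexyl entering. Among the compounds with values here, no measured pair shows this exchange on its own, so the expectation starts from compound 1 at 539 ug/mL and allows a wide range. In this assay the expectation is a small fall, a 1.3-fold lower number from compound 1 to compound 3 (0.13 log units; within the scatter) and so not beyond the scatter. Compound 3 is estimated at 400 ug/mL with an expected range from 170 ug/mL to 950 ug/mL for four of five measurements.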

Compound 3, solubility: >= 1000 ug/mL
Compound 3 ended at the assay's limit (the forecaster's own chance of this, stated with the estimate: 5%); middle value at least 2.5-fold (0.39 log units) away from the limit.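

In this assay compound 3 gives >= 1000 ug/mL, which is a limit of the assay and not a number. Within the data shown here, the exchange on the amide-type nitrogen, with 4-hydroxycyclohexyl entering in place of a group of the same heavy-atom and hydrogen-bond counts, provides the first single-place step, and it is only a floor: an at least 1.8-fold higher number from compound 1 to compound 3 (0.26 log units; that floor lies within the scatter). The full size of the step cannot be read because the reading stops at the top of the range: the limit of >= 1000 ug/mL in this assay, at which 1 of the 3 values shown sits.

On these data alone, how a 4-aminocyclohexyl or an unsubstituted cyclohexyl on the same nitrogen would read in this assay stays open. Among these compounds, also open is whether 4-hydroxycyclohexyl gives a similar step on the core of compound 2, which shares no single-place step with the other compounds.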